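The compounds below may be only part of what the source reports. "The series", "measured", "known", "first", "only" and "open" are said of these compounds alone.

Compound 1 `CC(=O)N[C@@H]1CCC[C@H](C(=O)Nc2cc(-c3cnn4c3CCCC4)ccn2)C1`: 33 uL/min
Compound 2 `CC(=O)N[C@@H]1CCC[C@H](C(=O)Nc2cc(-c3cnn4c3CCCCC4)c(Cl)cn2)C1`: 51 uL/min
Compound 3 `CC(=O)N[C@@H]1CCC[C@H](C(=O)Nc2cc(-c3cnn4c3CC(C)(C)CC4)ccn2)C1`: 35 uL/min

Three measured compounds share a core and differ in the bicyclic group and in a chloro group on the pyridine-type ring. In an ADME assay on cells (Hepatocyte, Rattus norvegicus) for metabolic stability, using equilibrium dialysis (on this read-out lower numbers stand for slow clearance and higher numbers for fast clearance), compound 2 sits at the top of the three numbers, yet its gap to compound 3 and its gap to compound 1 both lie within the usual scatter, so the three read as one level rather than a trend.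

Compound 4 `CC(=O)N[C@@H]1CCC[C@H](C(=O)Nc2cc(-c3cnn4c3CC(C)(C)C4)c(Cl)cn2)C1` differs from compound 2 by a group of 10 heavy atoms (8 carbon, 2 nitrogen; one five-membered non-aromatic ring with 1 hetero atom, one five-membered aromatic ring with 2 hetero atoms) in place of a group of 10 heavy atoms (8 carbon, 2 nitrogen; one five-membered aromatic ring with 2 hetero atoms, one seven-membered non-aromatic ring with 1 hetero atom), on an aromatic carbon. Among the compounds with values here, no step between measured compounds isolates a change of this kind, so there is nothing to calibrate it against. The expected step in this assay, a 1.1-fold lower number from compound 2 to compound 4 (0.05 log units; within the scatter), is one of no size beyond the scatter, in either direction. Compound 4 is therefore estimated at 45 uL/min, with a range from 25 uL/min to 80 uL/min.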

Compound 4, intrinsic clearance in a liver preparation (reported as CLH), per the amount of preparation that the assay uses: 73 uL/min
Beside the measured number, compound 4's estimate is 1.6-fold (0.21 log units) below it, and the stated range covers the measured number.
By their numbers in this assay, from the lowest: compounds 1, 3, 2 and 4 (each within the scatter of the next, the first and the last beyond it).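

In this assay the series now has its first single-place step: with the chloro group held, the five-membered non-aromatic ring in place of the seven-membered one gives a 1.4-fold higher number from compound 2 to compound 4 (0.16 log units; within the scatter) and so no separable change at this position. For this pair, the exchange of ring size does not move the read-out beyond the scatter. Nothing measured on hand bears on this result.

From the compounds shown here alone, whether the same exchange reads alike without the chloro group stays open. So does the effect of an amine or a carboxylic acid on the non-aromatic ring.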